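This account rests on a few compounds, and the source may have more. Where it says the series, first, only, none or still open, it means among the compounds named here.

Compound 1 `O=C(O)/C=C/c1ccc(Cn2cccn2)cc1OCCc1ccc2ccccc2c1` gives 12 nM in an assay on CHO cells for displacement of a labelled ligand from prostaglandin E2 receptor EP3 subtype (Mus musculus), read by scintillation counting; a lower number here means a stronger inhibitor, a higher number a weaker inhibitor. Compound 2 `COc1ccc(/C=C/C(=O)O)c(OCCC2(C)CCc3c(C)c(O)c(C)c(C)c3O2)c1` reaches only the limit of this assay, > 10000 nM. Compound 3 `O=C(O)C#Cc1ccc(Cn2cccn2)cc1OCCc1ccc2ccccc2c1` gives 99 nM in this assay, which is the higher of the two numbers shown; the nearest is compound 1, and the step of an 8.3-fold higher number from compound 1 to compound 3 (0.92 log units; beyond the scatter) ran beyond the usual scatter.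

Compound 4 `O=C(O)CCCc1ccc(Cn2cccn2)cc1OCCc1ccc2ccccc2c1` has not yet been measured in this assay. It differs from compound 3 in one place: 3-carboxypropyl in place of 2-carboxyethynyl on an aromatic carbon. Among the compounds with values here, the only measured step at this position is an 8.3-fold higher number from compound 1 to compound 3 (0.92 log units; beyond the scatter), which shows that a small change in the three-atom link to the acid can move the number by that much in either direction. The new chain has neither the double nor the triple bond of the earlier two, so the expectation is set between the two measured numbers with wide room on both sides. Compound 4 is therefore expected to give about 60 nM in this assay, within 15 nM to 300 nM, meaning an expected step of a 1.7-fold lower number from compound 3 to compound 4 (0.22 log units; within the scatter).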

Compound 4, inhibition constant: 39 nM
For compound 4 the middle estimate is 1.5-fold (0.19 log units) above the measured one; the measured number falls inside the stated range.
By their numbers in this assay, from the lowest: compound 1; then compound 4; then compound 3. At a limit, above all of these: compound 2.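

The change to 3-carboxypropyl gives a 2.5-fold lower number from compound 3 to compound 4 (0.40 log units; beyond the scatter) in this assay, so removing the triple bond from the chain carrying the acid recovers part of the loss seen with 2-carboxyethynyl. The same chain still gives a 3.3-fold higher number from compound 1 to compound 4 (0.51 log units; beyond the scatter), which leaves 2-carboxyethenyl with the lowest number of these three closely related compounds. This position therefore responds to the type of chain in both directions, and a chain with neither the double nor the triple bond of the earlier two remains usable, although it does not match compound 1. Going by these compounds, what a longer chain ending in the carboxylic acid, or a tetrazole in place of that acid, would give remains open. The compounds shown also offer no measured reason for these differences.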